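The source may report more compounds than this note shows. Statements on the series, on what has been measured and on what is new or still open speak of the compounds shown alone.

Measured in a functional assay on KB cells (Homo sapiens) for cytotoxicity; on this read-out lower numbers stand for an effect already at smaller amounts and higher numbers for an effect only at larger amounts of compound:
- compound 1 `COC1=C(C)C(=O)/C(=C(O)/C=C/c2cccc(OC)c2)C(=O)C1(C)C`: 3.3 ug/mL
- compound 2 `COC1=C(C)C(=O)/C(=C(O)/C=C/c2ccc(O)cc2)C(=O)C1(C)C`: 3.8 ug/mL
- compound 3 `COC1=C(C)C(=O)/C(=C(O)/C=C/c2c(C)cc(C)cc2C)C(=O)C1(C)C`: > 20 ug/mL (a limit, not a number)

For the measured compounds named here, compound 2 stands level with compound 1, the only other compound with a measured number: a 1.2-fold higher number from compound 1 to compound 2 (0.06 log units; within the scatter). Compound 3 offers only a limit, so it gives no step size.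

In compound 4 `COC1=C(C)C(=O)/C(=C(O)/C=C/c2ccco2)C(=O)C1(C)C`, furan-2-yl takes the place of 4-hydroxyphenyl on a double-bonded chain carbon bound to a double-bonded chain carbon: furan-2-yl in place of 4-hydroxyphenyl on a double-bonded chain carbon bound to a double-bonded chain carbon.

Going by the values given here, the one measured step that swaps the group there stayed within the scatter, so no step beyond the scatter is expected here. The estimated step is a 1.1-fold higher number from compound 2 to compound 4 (0.02 log units; within the scatter). For compound 4 the estimated value is 4 ug/mL, with an expected range from 1.5 ug/mL to 12 ug/mL.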

Compound 4, concentration for half-maximal effect: 9.9 ug/mL
Beside the measured number, compound 4's estimate is 2.5-fold (0.39 log units) below it, and the stated range covers the measured number.
By their numbers in this assay, from the lowest: compounds 1 and 2 (each within the scatter of the next); then compound 4. At a limit, above all of these: compound 3.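

The earlier swap at this position stayed within the scatter, but this one does not: furan-2-yl gives a 2.6-fold higher number from compound 2 to compound 4 (0.42 log units; beyond the scatter) and a 3.0-fold higher number from compound 1 to compound 4 (0.48 log units; beyond the scatter) on the same chain carbon. More compound is therefore needed for the effect with this five-membered aromatic ring than with either substituted six-membered aromatic ring, so the position is not indifferent to the group it carries. Nothing shown here explains this step.

As far as these compounds go, it remains open how a pyridin-3-yl or thiophen-2-yl ring would behave at this position, or a saturated cyclohexyl ring.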